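A few compounds are considered here, and "the series" means these few. Any claim that something is new, unique, unknown or untested is made for them only; others in the source may bear on it.

Of the compounds shown here, two have been tested in a functional assay on MCF7 cells (Homo sapiens), tested at 7.5 uM; a lower number here means a stronger effect, a higher number a weaker effect of the compound at the concentration tested. Compound 1, `C=CCOc1c(C)c(C)c2c(c1C)CCC(C)(COc1ccc(/C=C3\SC(=O)NC3=O)cc1Br)O2`, gives 105% in this assay. Compound 2, `COc1cc(/C=C2\SC(=O)NC2=O)ccc1OCC1(C)CCc2c(C)c(OCC=C(C)C)c(C)c(C)c2O1`, gives 54% in this assay, the lower of the two numbers and therefore the stronger effect, separated from compound 1 by a gap well beyond the scatter. Compound 3, `C=CCOc1c(C)c(C)c2c(c1C)CCC(C)(COc1ccc(/C=C3\SC(=O)NC3=O)cc1OC)O2`, has not yet been measured. It differs from compound 2 in one place: vinyl in place of 2-methylprop-1-en-1-yl on a saturated chain carbon bound to an oxygen on an aromatic ring. For the measured compounds named here, the shorter chain that enters is the one also carried by compound 1, while the methoxy group of compound 2 is kept. Going by the values given here, with no measured step of this kind to lean on, the expectation rests on compound 1 and compound 2 alone. The change from compound 2 to compound 3 is expected to weaken the effect by a number 21 percentage points higher from compound 2 to compound 3 (beyond the scatter), a step beyond the scatter but modest. Compound 3 is therefore estimated at 75%, with a likely range from 50% to 105%.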

Compound 3, a percentage reported as activity, at one concentration (the size of the read-out at that concentration, not a potency): 1%
Compound 3: middle estimate off by 74 percentage points, on the high side; the whole stated range lies above it.
By their numbers in this assay, from the lowest: compound 3; then compound 2; then compound 1.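

In this assay, compound 1 and compound 2 differ in two places, so they could not show what either change does alone, but compound 3 separates the two. Replacing 3-methylbut-2-en-1-yl with allyl on the ether oxygen, with methoxy kept on the aromatic ring, gives a large step, a number 53 percentage points lower from compound 2 to compound 3 (beyond the scatter), and replacing bromo with methoxy on the aromatic carbon, with allyl kept, gives an even larger one, a number 104 percentage points lower from compound 1 to compound 3 (beyond the scatter), so the effect responds strongly at both places. Nothing available explains why either change has so large an effect.

On these data alone, it remains open whether the double bond of allyl matters, which a saturated propyl chain would test. Whether an ethoxy group or an amine could stand in for methoxy is also unknown, and these single-concentration readings give no potency.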